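The source may report more compounds than this note shows. Statements on the series, on what has been measured and on what is new or still open speak of the compounds shown alone.

Measured so far in a functional assay on HepG2 cells (Homo sapiens) for cytotoxicity, read by MTT assay, with a stated time of 72 h; a higher number here means a weaker inhibitor, a lower number a stronger inhibitor
compound 1 `CNC(=O)c1cc(Oc2ccc(C3=NNC(c4ccc(Cl)cc4Cl)C3)cc2)ccn1` - "not determined" (no result reported)
compound 2 `CNC(=O)c1cc(Oc2ccc(C3=NNC(c4cccc([N+](=O)[O-])c4)C3)cc2)ccn1` - 26500 nM

Going by the values given here, compound 2 at 26500 nM holds the only number so far, and compound 1 has no result. Compound 3 `CNC(=O)c1cc(Oc2ccc(C3=NNC(c4ccc(F)cc4)C3)cc2)ccn1` carries 4-fluorophenyl in place of 3-nitrophenyl on a saturated ring carbon and awaits measurement. Among the compounds with values here, no measured step between compounds differing in one place is available to gauge this change, so in this assay no shift beyond the scatter is expected in either direction. The expected step of a 1.3-fold lower number from compound 2 to compound 3 (0.12 log units; within the scatter) is correspondingly small. Estimated for compound 3: 20000 nM with an expected range from 6000 nM to 60000 nM in this read-out.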

Compound 3, half-maximal inhibitory concentration: 5280 nM
For compound 3 the middle estimate is 3.8-fold (0.58 log units) above the measured one; the measured number lies below the stated range.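

In this assay, going by these compounds alone, replacing 3-nitrophenyl with 4-fluorophenyl on the saturated ring carbon gives a 5.0-fold lower number from compound 2 to compound 3 (0.70 log units; beyond the scatter) and provides the first readable step. This position therefore tolerates an aryl exchange while the number moves beyond the scatter. No available measurement accounts for this step.

Within the data shown here, the single step changes both the substituent and its place on the phenyl ring, so their contributions cannot be separated. As far as these compounds go, how an amine or a carboxylic acid on that phenyl ring would read remains open.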